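The source may report more compounds than this note shows. Statements on the series, on what has been measured and on what is new or still open speak of the compounds shown alone.

Measured so far:
- compound 1, `CCCCCNC(=O)/N=C(\N)NCCCc1sc(N)nc1C`, 178 nM
- compound 2, `N/C(=N\C(=O)NCc1ccccc1)NC1CCc2nc(N)sc2C1`, 4370 nM

Both were tested in a functional assay on HEK293T cells for agonist activity at histamine H2 receptor (Homo sapiens), read by beta-arrestin recruitment; a higher number here means that more compound is needed for the effect, a lower number that less compound is needed. Compound 1 stands lowest of the two numbers; its nearest neighbour, compound 2, gives a number a good deal higher, and that gap lies beyond the usual scatter of repeated measurements. Compound 2 also carries a different core, so its two values say nothing about any single change.

Compound 3, `Cc1nc(N)sc1CCCN/C(N)=N/C(=O)NCc1ccccc1`, is not yet measured. It differs from compound 1 in one place: phenyl in place of butyl on a saturated chain carbon bound to an amide-type nitrogen. Within the data shown here, no step between two measured compounds isolates this change, so the expected size of the step is uncertain. Compound 3 is expected to give 400 nM in this assay, within 120 nM to 1500 nM; this is an estimated step of a 2.2-fold higher number from compound 1 to compound 3 (0.35 log units; beyond the scatter), a modest rise that may well stay inside the scatter.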

Compound 3, half-maximal effective concentration: 100 nM
Compound 3: the middle estimate sits 4.0-fold (0.60 log units) above what was measured, and the stated range ends above it.
By their numbers in this assay, from the lowest: compounds 3 and 1 (each within the scatter of the next); then compound 2.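

In this assay, putting phenyl in place of butyl on a saturated chain carbon bound to an amide-type nitrogen gives a 1.8-fold lower number from compound 1 to compound 3 (0.25 log units; within the scatter). Among these compounds, this is the first direct look at this position, and it shows that an open chain and an aromatic ring of carbon can stand here without a change that this read-out can separate from the scatter. Nothing measured here explains why the two groups give values this close.

On these data alone, whether the position accepts other groups remains open: a saturated cyclohexyl ring, a longer chain such as heptyl, or a phenyl ring carrying an amine or a carboxylic acid could each give a different result. This single pair also cannot show whether the same exchange would have as small an effect on a different core.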